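The compounds below may be only part of what the source reports. "The series", "measured", "known", "first", "only" and "open" are said of these compounds alone.

Compound 1 `Fc1cccc(/C=N/NC(=S)Nc2cccc3ccccc23)c1F` is the point of departure of these notes. In a functional assay on A549 cells (Homo sapiens) for cytotoxicity, read by XTT assay, with a stated time of 24 h (a lower number here means a stronger inhibitor, a higher number a weaker inhibitor), compound 1 gives 500 ug/mL, the highest of the two numbers obtained so far. Compound 2 `Fc1ccc(Oc2ccc(/C=N/NC(=S)Nc3cccc4ccccc34)cc2)cc1` gives 62.5 ug/mL in this assay, the nearest number, and the gap between compound 1 and compound 2 lies beyond the usual scatter. Compound 3 `Fc1cc(F)c(/C=N/NC(=S)Nc2cccc3ccccc23)c(F)c1` reaches only a limit in this assay, recorded as > 500 ug/mL, which is a limit and not a number (the limit of > 500 ug/mL in this assay, at which 1 of the 3 values shown sits).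

Compound 4 `Fc1ccc(/C=N/NC(=S)Nc2cccc3ccccc23)cc1F` has not yet been measured. It differs from compound 1 in one place: 3,4-difluorophenyl in place of 2,3-difluorophenyl on a carbon with a double bond to nitrogen. Among the measured compounds shown here, no pair of measured compounds differs in a single place, so no step size is known from the set itself. The two compounds hold the same atoms joined differently, and the step of a 1.3-fold lower number from compound 1 to compound 4 (0.10 log units; within the scatter) is expected to stay within the scatter. Compound 4 is accordingly estimated at 400 ug/mL, with a range from 150 ug/mL to 900 ug/mL.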

Compound 4, half-maximal inhibitory concentration: 125 ug/mL
The estimate for compound 4 lay 3.2-fold (0.51 log units) above the measured number; measured number below the stated range.
By their numbers in this assay, from the lowest: compounds 2 and 4 (each within the scatter of the next); then compound 1.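

In this assay, 3,4-difluorophenyl in place of 2,3-difluorophenyl on a carbon with a double bond to nitrogen gives a 4.0-fold lower number from compound 1 to compound 4 (0.60 log units; beyond the scatter) on the shared core, so this position responds to the arrangement of the fluorines alone, with the atoms unchanged. Among the compounds shown here, this is the only single-place step so far, and it gives the series its one step size. No measurement shown bears on the cause of this step. As far as these compounds go, whether a methoxy group or an amine on the same phenyl ring would carry the number lower remains open. So does whether a single fluorine would serve as well as the 3,4-difluorophenyl group.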